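This account rests on a few compounds, and the source may have more. Where it says the series, first, only, none or still open, it means among the compounds named here.

Compound 1 (`CCc1cc(S(=O)(=O)N2C[C@H](c3ccccc3)NC2=O)ccc1NC(=O)c1ccc(N)cc1`) is the starting point. In a functional assay on HCT-116 cells (Homo sapiens) for cytotoxicity, read by MTT assay (on this read-out higher numbers stand for weaker inhibition and lower numbers for stronger inhibition), compound 1 gives 460 nM, the lowest of the two numbers in hand. Compound 3 (`CCOC(=O)Nc1ccc(S(=O)(=O)N2C[C@H](c3ccccc3)NC2=O)cc1F`) gives 5000 nM, a higher number that lies beyond the usual scatter. Compound 2 (`Cc1cc(S(=O)(=O)N2C(=O)N[C@@H](c3ccccc3)C2C)ccc1NC(=O)c1ccc([N+](=O)[O-])cc1`) sits at the limit of > 10000 nM in this assay, at which 1 of the 3 values shown sits, so its value of > 10000 nM is a limit of the assay rather than a number.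

Compound 4 (`CCc1cc(S(=O)(=O)N2C[C@H](c3ccccc3)NC2=O)ccc1NC(=O)OCC(C)C`) is compound 1 with isobutoxy in place of 4-aminophenyl on a carbonyl carbon. For the measured compounds named here, no measured pair differs by exactly this change. A weakening step is expected, a 6.5-fold higher number from compound 1 to compound 4 (0.81 log units; beyond the scatter), beyond the scatter, because compound 3 gives 5000 nM while compound 1 stays far lower. Compound 4 is therefore estimated at 3000 nM, between 800 nM and 10000 nM.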

Compound 4, half-maximal inhibitory concentration: 60 nM
Compound 4: middle estimate off by 50-fold (1.70 log units), on the high side; the measured number lies below the stated range.
By their numbers in this assay, from the lowest: compound 4; then compound 1; then compound 3. At a limit, above all of these: compound 2.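

In this assay, the 4-aminophenyl group on this carbonyl carbon proves not to be needed for a low number: isobutoxy, which has no ring, gives a 7.7-fold lower number from compound 1 to compound 4 (0.88 log units; beyond the scatter). At this place, then, an aromatic ring is not required, although this rests on a single pair. For the compounds shown here, nothing measured so far explains why the number falls. As far as these compounds go, it remains open how a shorter chain such as ethoxy, a longer chain such as hexyloxy, or a cyclic group such as cyclohexyloxy would read on the same carbonyl carbon.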